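A few compounds are considered here, and "the series" means these few. Any claim that something is new, unique, unknown or untested is made for them only; others in the source may bear on it.

In a functional assay (strain AB) with Danio rerio as the target, read by microscopy, with a stated time of 1 h (a higher number here means that more compound is needed for the effect, a lower number that less compound is needed), compound 1 `CCN1CCc2c(sc(NC(=O)Nc3ccc(Cl)cc3)c2C(N)=O)C1` gives 3120 nM, and compound 2 `NC(=O)c1c(NC(=O)Nc2ccc(Cl)cc2)sc2c1CCN(CC1CCCC1)C2` gives 1830 nM. The change between them, (methyl in place of cyclopentyl on a saturated chain carbon bound to an amine nitrogen in a ring), made a step of a 1.7-fold higher number from compound 2 to compound 1 (0.23 log units; within the scatter). Compound 3 `C[N+]1(CC2CCCC2)CCc2c(sc(NC(=O)Nc3ccc(Cl)cc3)c2C(N)=O)C1` gives 200 nM in this assay, the lowest number of the three; the difference between its core and that of compound 2 is not broken down here. Compound 4 `CC[N+]1(C)CCc2c(sc(NC(=O)Nc3ccc(Cl)cc3)c2C(N)=O)C1` has not yet been measured in this assay. It differs from compound 3 by methyl in place of cyclopentyl on a saturated chain carbon bound to an amine nitrogen in a ring, the same change, at the same place, that turned compound 2 into compound 1. Because that step was a 1.7-fold higher number from compound 2 to compound 1 (0.23 log units; within the scatter), the step from compound 3 to compound 4 in this assay is expected to be small, about a 1.7-fold higher number from compound 3 to compound 4 (0.23 log units; within the scatter). Compound 4 is therefore estimated at 340 nM, with a likely range from 150 nM to 800 nM.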

Compound 4, half-maximal effective concentration: 1960 nM
Estimate against measurement, compound 4: 5.8-fold (0.76 log units) below; measured number above the stated range.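

In this assay, methyl in place of cyclopentyl gave a 9.8-fold higher number from compound 3 to compound 4 (0.99 log units; beyond the scatter). Set beside the earlier step, the size of this change depends on the core that carries it: the same change on two cores in this assay, a 1.7-fold higher number (0.23 log units; within the scatter) from compound 2 to compound 1 and a 9.8-fold higher number (0.99 log units; beyond the scatter) from compound 3 to compound 4, 5.7-fold (0.76 log units) apart, beyond the scatter of two such steps Two pairs do not show which feature of the core accounts for this gap, nor how the change would behave on any further core in the series.

As far as these compounds go, it remains open whether a longer chain such as propyl or butyl, or a benzyl group, in the same place would give a number closer to that of compound 3 or that of compound 4. From the compounds shown here alone, it also remains open whether a cyclohexyl ring would behave like the cyclopentyl of compound 3.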